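Working notes: 4-chlorophenyl to 3-chlorophenyl swap

The source may report more compounds than this note shows. Statements on the series, on what has been measured and on what is new or still open speak of the compounds shown alone.

Values so far in a functional assay on MGC-803 cells (Homo sapiens) for cytotoxicity, read by MTT assay, with a stated time of 72 h (a higher number here means a weaker inhibitor, a lower number a stronger inhibitor), are as follows
- Compound 1 `O=C(CSC(=S)N[C@H]1CCOC1=O)Nc1ccc(O)cc1` gives 80000 nM
- Compound 2 `O=C(CCl)Nc1ccc(C(=O)/C=C/c2ccc(Cl)cc2)cc1` gives 4960 nM

Compound 2 at 4960 nM holds the lower of the two numbers, and compound 1 at 80000 nM lies beyond the scatter from it. These two compounds differ in more than one place, so their gap gives no guide to a single change.

Compound 3 `O=C(CCl)Nc1ccc(C(=O)/C=C/c2cccc(Cl)c2)cc1` has not yet been measured. Its difference from compound 2 is 3-chlorophenyl in place of 4-chlorophenyl on a double-bonded chain carbon bound to a double-bonded chain carbon and amounts to 3-chlorophenyl in place of 4-chlorophenyl on a double-bonded chain carbon bound to a double-bonded chain carbon. Among the measured compounds shown here, no measured pair shows the effect of such a change in this assay and any expectation is therefore weak. Compound 2 at 4960 nM is the anchor: compound 3 has the same atoms, joined differently, and no step beyond the scatter is expected, with a slight lean toward a higher number. The estimated step is a 1.2-fold higher number from compound 2 to compound 3 (0.08 log units; within the scatter) and would stay within the scatter. For compound 3 the estimated value is 6000 nM with 2500 nM to 14000 nM as the expected range.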

Compound 3, half-maximal inhibitory concentration: 2010 nM
Compound 3: the middle estimate sits 3.0-fold (0.47 log units) above what was measured, outside the stated range (below it).
By their numbers in this assay, from the lowest: compound 3; then compound 2; then compound 1.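

In this assay, among the compounds shown here, the swap of 4-chlorophenyl for 3-chlorophenyl on a double-bonded chain carbon bound to a double-bonded chain carbon gives a 2.5-fold lower number from compound 2 to compound 3 (0.39 log units; beyond the scatter) and is the first single-place comparison. The entering and leaving groups have the same heavy atoms, the same aromatic ring and the same hydrogen-bond counts, so the read-out at this position responds to where the chlorine stands on the ring, even with the composition unchanged. No available measurement accounts for this step, and its cause remains unassigned.

The compounds shown leave open whether the step reflects something specific to chlorine or would also appear with another group on the ring at this place, such as bromine, a methoxy group, an amine or a carboxylic acid. From the compounds shown here alone, they also rest this reading on one pair in one cell line, so it remains unknown whether the same swap would give a step of similar size on a different core or in another assay.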